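Cyclopropyl for Carbamate on the Benzyl Ring

This account rests on a few compounds, and the source may have more. Where it says the series, first, only, none or still open, it means among the compounds named here.

Three compounds have been measured in an assay on isolated protein for activation of cGMP-dependent protein kinase 1 (Homo sapiens), read by ADP-Glo, with stated times of 30 min and 2 h, in the presence of a further agent that is not named here; a higher number here means that more compound is needed for the effect, a lower number that less compound is needed:
compound 1 `COC(=O)c1ccc(CN2CCC[C@H](O[C@H](CO)c3cc(Cl)cc(Cl)c3)[C@@H]2c2ccccc2)c(C)c1` gives 900 nM;
compound 2 `O=C(O)c1ccc2nc(CN3CCC[C@H](O[C@H](CO)c4cc(Cl)cc(Cl)c4)[C@@H]3c3ccccc3)[nH]c2c1` gives 380 nM;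
compound 3 `COC(=O)Nc1cc(C(=O)O)ccc1CN1CCC[C@H](O[C@H](CO)c2cc(Cl)cc(Cl)c2)[C@@H]1c1ccccc1` gives 1000 nM.

Compound 3 has the highest number of the three. Its number and that of compound 1 lie within the scatter of each other, so nothing separates them; compound 2 sits beyond the scatter below compound 3.

Compound 4 `O=C(O)c1ccc(CN2CCC[C@H](O[C@H](CO)c3cc(Cl)cc(Cl)c3)[C@@H]2c2ccccc2)c(C2CC2)c1` has not yet been measured. It differs from compound 3 in one place: cyclopropyl in place of (methoxycarbonyl)amino on an aromatic carbon.

Among the compounds with values here, the only measured step, a 2.4-fold lower number from compound 1 to compound 2 (0.37 log units; beyond the scatter), exchanges the whole group on the ring nitrogen and says little about a change of one substituent on the benzyl ring. Compound 1 and compound 3, which carry different substituents there, show no difference beyond the scatter. So no step beyond the scatter is expected for this change, and compound 4 is estimated at 800 nM, within 300 nM to 2500 nM, an expected 1.3-fold lower number from compound 3 to compound 4 (0.10 log units; within the scatter).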

Compound 4, half-maximal effective concentration: 1800 nM
Compound 4: middle estimate off by 2.3-fold (0.35 log units), on the low side; low and high end bracket the measured number.
By their numbers in this assay, from the lowest: compound 2; then compounds 1, 3 and 4 (each within the scatter of the next).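

Putting cyclopropyl in place of (methoxycarbonyl)amino on this aromatic carbon gives a 1.8-fold higher number from compound 3 to compound 4 (0.26 log units; within the scatter), so a smaller group with no hydrogen-bond donor or acceptor is not separated here from the group it replaces. Within the data shown here, changing the whole group on the ring nitrogen gives a 2.0-fold higher number from compound 1 to compound 4 (0.30 log units; within the scatter), while a 4.7-fold higher number from compound 2 to compound 4 (0.68 log units; beyond the scatter) is the only new step that goes beyond the scatter. Nothing available here accounts for these numbers.

The first of those two whole-group steps changes both the ring substituent and the methoxycarbonyl group that becomes a carboxy group, so it does not isolate either change. The compounds shown leave open what an amine or a methoxy group on this same aromatic carbon would give, and whether any group there can move the number beyond the scatter.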